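Shifting the nitrile around the phenyl ring in a dihydropyridine

The source may hold more compounds than are shown below. What is called first, only, known or untested is meant among the compounds shown, and "the series" means these compounds.

Compound 2 `COC(=O)C1=C(C)N=C(C)/C(=C(\O)OC)C1c1ccccc1C#N` stands highest of the two numbers recorded in a functional assay (muscle tissue) with Cavia porcellus as the target (on this read-out higher numbers stand for an effect only at larger amounts of compound and lower numbers for an effect already at smaller amounts), where compound 2 gives 15.9 nM. Among the measured compounds shown here, its nearest neighbour is compound 1 `COC(=O)C1=C(C)N=C(C)/C(=C(\O)OC)C1c1ccccc1Cl`, and in this assay compound 1 gives 2.19 nM; the only recorded step, a 7.3-fold higher number from compound 1 to compound 2 (0.86 log units; beyond the scatter), came from cyano in place of chloro on an aromatic carbon. Compound 3 `COC(=O)C1=C(C)N=C(C)/C(=C(\O)OC)C1c1cccc(C#N)c1` is not yet measured in this assay. It differs from compound 2 in that (3-cyanophenyl in place of 2-cyanophenyl on a saturated ring carbon). For the measured compounds named here, no recorded step moves a group to another position on the same aromatic ring, so the step from compound 1 to compound 2 does not bear directly on this change, and the expectation rests on the structures alone. A small rise in the number, near the edge of the scatter, is expected, a 1.9-fold higher number from compound 2 to compound 3 (0.28 log units; within the scatter). Compound 3 is therefore estimated at 30 nM, with a likely range from 8 nM to 120 nM.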

Compound 3, half-maximal effective concentration: 34.7 nM
Beside the measured number, compound 3's estimate is 1.2-fold (0.06 log units) below it; the range from low to high includes it.
By their numbers in this assay, from the lowest: compound 1; then compound 2; then compound 3.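

Moving the nitrile, with the same atoms joined differently, is enough to shift the read-out in this assay: the change from 2-cyanophenyl to 3-cyanophenyl gives a 2.2-fold higher number from compound 2 to compound 3 (0.34 log units; beyond the scatter), so where the group sits on the ring counts here, and not only which group it is. Measured against the chloro starting point, the same position gives a 16-fold higher number from compound 1 to compound 3 (1.20 log units; beyond the scatter), which leaves compound 3 with the highest number of the three and compound 1 with the lowest. Nothing at hand offers a reason for this shift.

The compounds shown leave open whether chloro, moved around the phenyl ring in the same way, would follow the nitrile. They also leave open how an amine or a carboxylic acid on that ring would read in this assay.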